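Exchanging the Aryl Group on the Urea Nitrogen

The compounds below may be only part of what the source reports. "The series", "measured", "known", "first", "only" and "open" are said of these compounds alone.

Of the compounds shown here, two built on a shared core have been tested in a functional assay on NCI/ADR-RES cells (Homo sapiens) for inhibition, read by sulforhodamine B assay, with a stated time of 48 h, tested at 0.1 uM; a lower number here means a stronger effect, a higher number a weaker effect of the compound at the concentration tested. Compound 1 (`COc1cc(Cl)cc(-c2nn(-c3cccc(NC(=O)Nc4cc(C(F)(F)F)cc(C(F)(F)F)c4)c3)cc2-c2ccncc2)c1`) carries a 3,5-bis(trifluoromethyl)phenyl group on the amide-type nitrogen and in this assay gives 95%. Compound 2 (`COc1cc(Cl)cc(-c2nn(-c3cccc(NC(=O)Nc4ccc(Cl)c(Cl)c4)c3)cc2-c2ccncc2)c1`) carries a 3,4-dichlorophenyl group in the same place and gives 98%. Compound 2 thus stands at the top of the two numbers, but the gap to compound 1 lies within the scatter of the assay, so the two values cannot be told apart; both show almost no inhibition at the concentration tested.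

Compound 3 (`COc1cc(Cl)cc(-c2nn(-c3cccc(NC(=O)Nc4cccc(C(F)(F)F)c4)c3)cc2-c2ccncc2)c1`) has not yet been measured. It differs from compound 2 in one place: 3-(trifluoromethyl)phenyl in place of 3,4-dichlorophenyl on an amide-type nitrogen. Since compound 1 and compound 2 read alike in this assay despite different aryl groups on that nitrogen, no step beyond the scatter is expected from compound 2 to compound 3, in either direction. The expected step is a number 2 percentage points lower from compound 2 to compound 3 (within the scatter). Compound 3 is accordingly estimated to give 96% in this assay, within a range from 84% to 106%.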

Compound 3, a percentage reported as activity, at one concentration (the size of the read-out at that concentration, not a potency): 98%
For compound 3 the middle estimate is 2 percentage points below the measured one, and the stated range covers the measured number.
By their numbers in this assay, from the lowest: compounds 1, 2 and 3 (each within the scatter of the next).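

The exchange of 3,4-dichlorophenyl for 3-(trifluoromethyl)phenyl on the amide-type nitrogen brings no change at the digits printed from compound 2 to compound 3 (within the scatter) in this assay, and hydrogen in place of trifluoromethyl on an aromatic carbon brings a number 3 percentage points higher from compound 1 to compound 3 (within the scatter). Within the data shown here, the second step gives the first comparison in which the aryl group on this nitrogen changes at one substituent only, and it shows that losing one of the two trifluoromethyl groups leaves the read-out within the scatter, while the first step shows the same for a swap of the substituents on the ring. All three aryl groups therefore read alike at the concentration tested, and the result offers no ranking among them; no measurement at hand bears on why these compounds read as they do.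

The compounds shown all keep a substituted phenyl ring on this nitrogen, so it remains open whether a carboxylic acid, an aminomethyl group or a longer alkyl chain on that ring would separate from them. From the compounds shown here alone, whether the three aryl groups would also read alike at a higher concentration also stays open.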